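A Weak Antiproliferative Amide and One Halogen Swap

This account rests on a few compounds, and the source may have more. Where it says the series, first, only, none or still open, it means among the compounds named here.

Compound 1 `O=C(COc1ccc(C(=O)/C=C/c2ccc(Cl)cc2Cl)cc1)N[C@H]1CCOC1=O` carries a 2,4-dichlorophenyl group at the far end of an unsaturated chain, joined through an ether and an amide to a small ring. Among the measured compounds shown here, in a functional assay on MCF7 cells (Homo sapiens) for antiproliferative activity, read by MTT assay, with a stated time of 72 h (on this read-out higher numbers stand for weaker inhibition and lower numbers for stronger inhibition), compound 1 gives 34400 nM, which is the only definite number among the three measured compounds and marks weak inhibition. Compound 2 `Cc1ccc(C(C)C)c(OCCSC(=S)N[C@H]2CCOC2=O)c1` has a different linker and a different aromatic end. For compound 2 this assay reports only a limit, > 64000 nM, and no number. Compound 3 `O=C1OCC[C@@H]1NC(=S)SCCOc1cccc2ccccc12` is built on the same linker as compound 2 with a larger aromatic end. For compound 3 this assay likewise reports only a limit, > 64000 nM. For the measured compounds named here, that limit, (the limit of > 64000 nM in this assay, at which 2 of the 3 values shown sit), is where two of the three known values rest, so compound 1 stands alone as the single compound with a measured value, and even that value is high.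

Compound 4 `O=C(COc1ccc(C(=O)/C=C/c2ccccc2Br)cc1)N[C@H]1CCOC1=O` differs from compound 1 in one place: 2-bromophenyl in place of 2,4-dichlorophenyl on a double-bonded chain carbon bound to a double-bonded chain carbon. Going by the values given here, no measured pair of compounds differs in just this way, so there is no step to lean on. Exchanging one halogen-bearing ring for another is expected to move the number little, if at all, beyond the scatter. Compound 4 is therefore estimated at 40000 nM, with a range from 15000 nM to 100000 nM. The expected step, a 1.2-fold higher number from compound 1 to compound 4 (0.07 log units; within the scatter), is small.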

Compound 4, half-maximal inhibitory concentration: 15300 nM
For compound 4 the middle estimate is 2.6-fold (0.42 log units) above the measured one, and the stated range covers the measured number.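

In this assay, among the compounds shown here, 2-bromophenyl in place of 2,4-dichlorophenyl gives a 2.2-fold lower number from compound 1 to compound 4 (0.35 log units; beyond the scatter), a modest change but the first step that can be read in this set. It shows that the number responds to the ring on a double-bonded chain carbon bound to a double-bonded chain carbon, even when the exchange is only between halogen-bearing rings, and that the lower number here means stronger inhibition. The two groups are alike in what can be counted, as each is a six-membered aromatic ring of carbon only with no hydrogen-bond donors or acceptors, but this single step cannot tell whether the loss of the two chlorines or the arrival of the bromine moves the number.

For the compounds shown here, compound 2 and compound 3 offer no step to read, since each differs from the others in more than one place and each rests on a limit rather than a number: the limit of > 64000 nM in this assay, at which 2 of the 4 values shown sit. It remains open whether an unsubstituted phenyl ring, or a ring carrying an amine or a carboxylic acid, at this same place would move the number further in either direction.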